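Chloro to Iodo on an Aromatic Carbon

This account rests on a few compounds, and the source may have more. Where it says the series, first, only, none or still open, it means among the compounds named here.

Measured so far:
compound 1, `NC(=O)COc1ccccc1Cc1cnc(N)nc1N` — 33900 nM
compound 2, `Nc1ncc(Cc2ccccc2Cl)c(N)n1` — 17400 nM

Of the compounds shown here, two have been tested in an assay for inhibition of Dihydrofolate reductase (Gallus gallus); on this read-out lower numbers stand for stronger inhibition and higher numbers for weaker inhibition. Compound 2 gives the lowest of the two numbers; its nearest neighbour is compound 1, and the step of a 1.9-fold lower number from compound 1 to compound 2 (0.29 log units; within the scatter) lies within the scatter, so the two cannot be ranked. Compound 3, `Nc1ncc(Cc2ccccc2I)c(N)n1`, has not been measured. It differs from compound 2 in one place: iodo in place of chloro on an aromatic carbon. Within the data shown here, no measured step exchanges one halogen for another; the only step known, from compound 1 to compound 2, swaps carbamoylmethoxy for chloro and is itself within the scatter. Nothing here therefore points to a change beyond the scatter in this assay. The estimated step is a 1.5-fold lower number from compound 2 to compound 3 (0.16 log units; within the scatter). For compound 3 the expected value in this assay is 12000 nM, within a range of 4000 nM to 35000 nM.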

Compound 3, inhibition constant: 8710 nM
For compound 3 the middle estimate is 1.4-fold (0.14 log units) above the measured one; measured number inside the range.
By their numbers in this assay, from the lowest: compounds 3, 2 and 1 (each within the scatter of the next, the first and the last beyond it).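

In this assay, among these compounds, the exchange of chloro for iodo gives the first step between two halogens on this aromatic carbon, and a 2.0-fold lower number from compound 2 to compound 3 (0.30 log units; within the scatter) leaves the two compounds unranked. Iodo in place of carbamoylmethoxy gives a 3.9-fold lower number from compound 1 to compound 3 (0.59 log units; beyond the scatter) at the same place, a modest change but the first here beyond the scatter, which chloro in compound 2 did not reach against compound 1. No available evidence bears on the reason for these numbers.

The compounds shown leave open how fluoro or bromo would compare at this place, so two halogens do not yet make a trend. They also leave open whether an amine, a carboxylic acid or a longer alkoxy chain there would match the halogens or fall nearer to carbamoylmethoxy.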